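The source may hold more compounds than are shown below. What is called first, only, known or untested is meant among the compounds shown, and "the series" means these compounds.

Measured so far:
compound 1 `[N-]=[N+]=NCc1ncnc2c1ncn2[C@@H]1O[C@H](CO)[C@@H](O)[C@H]1O`: 1880 nM
compound 2 `CN(Cc1ncnc2c1ncn2[C@@H]1O[C@H](CO)[C@@H](O)[C@H]1O)c1ccccc1`: 4000 nM
compound 3 `CC(C)N(Cc1ncnc2c1ncn2[C@@H]1O[C@H](CO)[C@@H](O)[C@H]1O)C(C)C`: 13000 nM

All three compounds share one core and differ only in the group on the saturated chain carbon bound to an aromatic carbon. In a functional assay on HL-60 cells (Homo sapiens) for inhibition, with a stated time of 72 h (a higher number here means a weaker inhibitor, a lower number a stronger inhibitor), compound 3 stands highest of the three numbers. The two steps leading to it, a 6.9-fold higher number from compound 1 to compound 3 (0.84 log units; beyond the scatter) and a 3.3-fold higher number from compound 2 to compound 3 (0.51 log units; beyond the scatter), both lie beyond the scatter, as does a 2.1-fold higher number from compound 1 to compound 2 (0.33 log units; beyond the scatter). Within this small set, the larger the group at that position, the higher the number, and no compound goes against that order.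

Compound 4 `COCc1ncnc2c1ncn2[C@@H]1O[C@H](CO)[C@@H](O)[C@H]1O` has not yet been measured. It differs from compound 3 by methoxy in place of diisopropylamino on a saturated chain carbon bound to an aromatic carbon. Among the measured compounds shown here, the steps that bear on this change are the two arriving at compound 3: a 6.9-fold higher number from compound 1 to compound 3 (0.84 log units; beyond the scatter) and a 3.3-fold higher number from compound 2 to compound 3 (0.51 log units; beyond the scatter), each replacing a smaller group by the diisopropylamino group and each raising the number. Compound 4 carries a group even smaller than those of compound 1 and compound 2, so a step downward, back toward the number of compound 1, is expected rather than none.

Compound 4 is therefore estimated at 2500 nM in this assay, with a range from 800 nM to 8000 nM. The expected step is a 5.2-fold lower number from compound 3 to compound 4 (0.72 log units; beyond the scatter).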

Compound 4, half-maximal inhibitory concentration: 13000 nM
For compound 4 the middle estimate is 5.2-fold (0.72 log units) below the measured one; measured number outside the range, above it.
By their numbers in this assay, from the lowest: compound 1; then compound 2; then compounds 3 and 4 (each within the scatter of the next).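

In this assay, methoxy, with 2 heavy atoms against 7 for diisopropylamino, gives no change at the digits printed from compound 3 to compound 4 (within the scatter) and so breaks the link between group size and number that held among the first three compounds; compound 4 is the one that goes against that order. The steps of a 6.9-fold higher number from compound 1 to compound 4 (0.84 log units; beyond the scatter) and a 3.3-fold higher number from compound 2 to compound 4 (0.51 log units; beyond the scatter) show that a small group on the saturated chain carbon bound to an aromatic carbon does not by itself keep the number low, and that azido and methyl(phenyl)amino both stand lower here than methoxy, although methyl(phenyl)amino is the larger group. Nothing measured here accounts for why methoxy and diisopropylamino, so unlike in size, stand level in this assay.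

The compounds shown leave open how a hydroxyl, a primary amine or an ethoxy group would stand on this carbon, and so whether methoxy is a lone case or belongs to a wider family of groups. They also leave open whether a smaller amine such as dimethylamino would fall nearer compound 1 or nearer compound 3.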